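The source may report more compounds than this note shows. Statements on the series, on what has been measured and on what is new or still open speak of the compounds shown alone.

Measured compounds:
- compound 1 `CC(C)(C)c1cc(NC(=O)Nc2ccc(-c3cn4ccccc4n3)cc2)no1`: 3.09 nM
- compound 2 `CC(C)(C)c1cc(NC(=O)Nc2ccc(-c3cn4ncccc4n3)cc2)no1`: 59.1 nM

In a functional assay on MV4-11 cells (Homo sapiens) for cytotoxicity, read by MTT assay, with a stated time of 72 h (on this read-out lower numbers stand for stronger inhibition and higher numbers for weaker inhibition), compound 1 gives 3.09 nM and compound 2 gives 59.1 nM. Going by the values given here, compound 2 therefore stands at the highest of the two numbers, with compound 1 as its only neighbour, a large step below it.

Compound 3 `CC(C)(C)c1cc(NC(=O)Nc2ccc(-c3cc4ccccc4s3)cc2)no1` has not been measured. It differs from compound 2 by a group of 9 heavy atoms (8 carbon, 1 sulfur; one five-membered aromatic ring with 1 hetero atom, one six-membered aromatic ring of carbon only) in place of a group of 9 heavy atoms (6 carbon, 3 nitrogen; one five-membered aromatic ring with 2 hetero atoms, one six-membered aromatic ring with 2 hetero atoms), on an aromatic carbon; the change sits on an aromatic carbon of a six-membered aromatic ring of carbon only, para to a large group.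

Among the compounds with values here, only one measured step bears on this position: a 19-fold higher number from compound 1 to compound 2 (1.28 log units; beyond the scatter). That step added a nitrogen to the six-membered ring of the two-ring group at this carbon and raised the number sharply. Within the data shown here, the change to compound 3 removes both nitrogens from the six-membered ring and also swaps the five-membered ring for one with a single sulfur, so it is not a simple reversal, and the effect of the sulfur-containing ring has no precedent here.

The expectation for compound 3 is still a lower number, a 7.4-fold lower number from compound 2 to compound 3 (0.87 log units; beyond the scatter), roughly back toward compound 1. The estimate for compound 3 is 8 nM, with a range of 2 nM to 40 nM.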

Compound 3, half-maximal inhibitory concentration: > 900 nM
Compound 3 was reported as a limit; the forecaster's own chance of this, stated with the estimate: 2%; middle value at least 110-fold (2.05 log units) from the limit.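

In this assay compound 3 is reported only as a limit, not as a number: the limit of > 900 nM in this assay, at which 1 of the 3 values shown sits. Placing 1-benzothiophen-2-yl on this aromatic carbon gives an at least 15-fold higher number from compound 2 to compound 3 (1.18 log units; beyond the scatter), and an at least 290-fold higher number from compound 1 to compound 3 (2.46 log units; beyond the scatter), so removing the nitrogens from the six-membered ring of the two-ring group does not restore the low number of compound 1. The group count of 9 heavy atoms is the same in all three compounds, yet the values do not follow the number of hetero atoms in the six-membered ring: compound 1, with one, has the lowest value, while compound 2, with two, falls in the middle and compound 3, with none, sits at the limit.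

The compounds shown do not separate the contribution of the sulfur in the five-membered ring from that of the lost ring nitrogens, and the limit leaves the full size of both new steps open. Also open, going by these compounds, is how this carbon would respond to a 1-benzofuran-2-yl group, with oxygen in place of sulfur, or to a two-ring group carrying an amine.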